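A few compounds are considered here, and "the series" means these few. Any claim that something is new, unique, unknown or untested is made for them only; others in the source may bear on it.

Measured compounds:
- compound 1 `CCC(C(=O)N1CCN(c2cccc(C(F)(F)F)c2)CC1)N1C(=O)CC(C)C1=O`: in a functional assay on the whole organism (strain Swiss) with Mus musculus as the target, in the maximal electroshock model, with a stated time of 0.25 h (a higher number here means that more compound is needed for the effect, a lower number that less compound is needed), compound 1 gives 75.1 mg/kg
- compound 2 `CC(C(=O)N1CCN(c2ccccc2C(F)(F)F)CC1)N1C(=O)CC(C)(C)C1=O`: in this assay compound 2 gives only a limit, > 130 mg/kg

Among the measured compounds shown here, compound 1 stands as the only compound with a definite number in this assay; the other value is a limit (the limit of > 130 mg/kg in this assay, at which 1 of the 2 values shown sits), at which compound 2 sits, so no measured step can be placed between the two and nothing can be said about the size or direction of a change between them.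

The unmeasured compound 3 `CC1CC(=O)N(C(C)C(=O)N2CCN(c3cccc(C(F)(F)F)c3)CC2)C1=O` is derived from compound 1 by a single change: hydrogen in place of methyl on a saturated chain carbon, two bonds along the chain from an amide-type nitrogen in a ring and a carbonyl carbon. For the measured compounds named here, no measured pair shows this exact change. Going by the values given here, the limit of compound 2, which also carries the shorter chain but differs in more than one place, offers no guidance on the step.

Compound 3 is therefore expected to stay close to compound 1, with an estimated shift of a 1.3-fold higher number from compound 1 to compound 3 (0.10 log units; within the scatter) that would not clearly exceed the scatter. Compound 3 is estimated at 95 mg/kg, with a range from 45 mg/kg to 200 mg/kg.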

Compound 3, dose for half-maximal effect: 81.7 mg/kg
The estimate for compound 3 lay 1.2-fold (0.07 log units) above the measured number; measured number inside the range.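

In this assay the change from ethyl to methyl on a saturated chain carbon, two bonds along the chain from an amide-type nitrogen in a ring and a carbonyl carbon, gives a 1.1-fold higher number from compound 1 to compound 3 (0.04 log units; within the scatter) and so leaves the two compounds indistinguishable in this read-out. Among the compounds shown here, this is the first step that can be read, and it shows that, on the core of compound 1, the shorter chain at this place keeps the dose needed for the effect within the usual scatter of the measurement. No measurement shown gives a cause for this result.

As far as these compounds go, it remains open whether a longer chain such as propyl, a branched chain such as isopropyl, or a chain carrying an amine or a carboxylic acid at this place would also stay within the scatter in this assay, and whether hydrogen could replace the methyl of compound 3 on the same carbon. Also open, from the compounds shown here alone, is whether the same step would read alike on a core that carries a nitrile in place of the trifluoromethyl.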